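Acyl group on the ring nitrogen: outlook for compound 3

This account rests on a few compounds, and the source may have more. Where it says the series, first, only, none or still open, it means among the compounds named here.

Measured so far:
compound 1 `COc1ccc(C2CC(c3ccc(OC)c(OC)c3)=NN2)c(OC)c1`: 38%
compound 2 `COc1ccc(C2=NN(C(=O)CBr)C(c3c(Cl)cccc3Cl)C2)cc1OC`: 48%

Both numbers come from a functional assay on the whole organism (strain albino) for inhibition, with Rattus norvegicus as the target, read by paw edema, with stated times of 30 min and 1 h, at a dose of 100 mg/kg by the oral route; a higher number here means more inhibition at the dose given (going by the name of the read-out), a lower number less inhibition. Compound 1 stands lowest of the two; the nearest number is that of compound 2, and the gap between the two lies within the scatter. Among the compounds with values here, no pair of measured compounds differs in only one place, so no single step is known from the data.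

Compound 3 `COc1ccc(C2CC(c3ccc(OC)c(OC)c3)=NN2C(=O)CO[N+](=O)[O-])c(OC)c1` is not yet measured. It differs from compound 1 by ((nitrooxy)methyl)carbonyl in place of hydrogen on an amine nitrogen in a ring. Compound 2, which also carries a carbonyl group on the ring nitrogen, gives 48% in this assay, within the scatter of the number for compound 1. On that basis the expected step is a number 7 percentage points higher from compound 1 to compound 3 (within the scatter), upward if at all and likely not beyond the scatter. Compound 3 is estimated at 45%, with a range from 30% to 62%.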

Compound 3, a percentage reported as inhibition, in the whole organism at one dose (the size of the read-out at that dose, not a potency): 38%
For compound 3 the middle estimate is 7 percentage points above the measured one; the range from low to high includes it.
By their numbers in this assay, from the lowest: compounds 1, 3 and 2 (each within the scatter of the next).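

In this assay, within the data shown here, placing ((nitrooxy)methyl)carbonyl in place of hydrogen on the amine nitrogen in the ring gives no change at the digits printed from compound 1 to compound 3 (within the scatter) and provides the first single-place step. This position therefore accepts this acyl group without a change beyond the scatter, and in this pair the hydrogen on that nitrogen is not required for the inhibition seen at the one dose tested. No available evidence bears on why the step is this small.

Among these compounds, it remains open whether the carbonyl and the nitrooxy end each have an effect that the single step conceals; an acetyl or a hydroxyacetyl group on the same nitrogen would separate the two. On these data alone, the response of compound 1 and compound 3 at other doses also remains open, as does the effect of an amine at the end of a longer acyl chain.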